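Kinetic Solubility: From Compound 2 Toward Compound 3

The source may hold more compounds than are shown below. What is called first, only, known or untested is meant among the compounds shown, and "the series" means these compounds.

Measured so far:
- compound 1, `COc1ccc2nc(C(F)(F)F)cc(OCC(=O)Nc3cc(C)cc(C)c3)c2c1`: 15000 nM
- compound 2, `COc1ccc2nc(C)cc(OCC(=O)Nc3cccc(C)c3)c2c1`: 193000 nM

In a physicochemical assay for solubility, in phosphate buffer, measured as kinetic solubility, with a stated time of 1 h, at pH 7.4 (a higher number here means a more soluble compound, a lower number a less soluble compound), compound 2 gives 193000 nM, the higher of the two numbers measured, while compound 1 gives 15000 nM, a difference that lies beyond the usual scatter. Compound 3, `COc1ccc2nc(C)cc(OCC(=O)Nc3ccc(Cl)c(OC)c3)c2c1`, has not yet been measured in this assay. It differs from compound 2 in one place: 4-chloro-3-methoxyphenyl in place of 3-methylphenyl on an amide-type nitrogen. Going by the values given here, with no measured pair that isolates this change, only an expectation is possible. The estimated step of a 2.8-fold lower number from compound 2 to compound 3 (0.44 log units; beyond the scatter) is a moderate decrease, likely beyond the scatter but far smaller than the gap seen between compound 2 and compound 1. For compound 3 the expected value is 70000 nM, with a range from 25000 nM to 180000 nM.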

Compound 3, solubility: 13000 nM
Beside the measured number, compound 3's estimate is 5.4-fold (0.73 log units) above it; measured number below the stated range.
By their numbers in this assay, from the lowest: compounds 3 and 1 (each within the scatter of the next); then compound 2.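

In this assay, the exchange on the amide-type nitrogen gives a 15-fold lower number from compound 2 to compound 3 (1.17 log units; beyond the scatter) with the rest of the molecule unchanged, so this position alone can produce a large step. Compound 1 and compound 2 differ in more than one place, so their gap could not be tied to a single group, whereas this step belongs to one exchange: 4-chloro-3-methoxyphenyl in place of 3-methylphenyl. Nothing in the available data accounts for the size of this drop.

The chlorine and the methoxy group enter together, so the compounds shown leave open how much of the step goes with each of them. Also open, as far as these compounds go, is how the read-out would respond to an amine or a carboxylic acid on the phenyl ring at this position.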